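The source may hold more compounds than are shown below. What is called first, only, known or untested is meant among the compounds shown, and "the series" means these compounds.

Measured so far in a functional assay on the whole organism with Rattus norvegicus as the target, in the glucose tolerance test; on this read-out higher numbers stand for an effect only at larger amounts of compound and lower numbers for an effect already at smaller amounts:
- compound 1, `CCCCCCCCCCCCCCC1(C(=O)OCCCC)CO1`: 1.5 mg/kg
- compound 2, `CCCCCCCCCCCCCCCCCCCCCCC1(C(=O)OC)CO1`: 10 mg/kg

Compound 2 stands highest of the two numbers; its nearest neighbour is compound 1, whose number is lower by a margin beyond the usual scatter. The two differ in more than one place, so their values are compared only as they stand, without a counted step.

Compound 3, `CCCCCCCCCCCCCCCCCCC1(C(=O)OC)CO1`, is not yet measured. The change from compound 2 to compound 3 is hydrogen in place of butyl on a saturated chain carbon, ten or more bonds along the chain from a saturated ring carbon.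

Within the data shown here, no single-point step is known, so the size of the coming step rests on the two values alone. Compound 1, carrying a shorter chain and the lower number, suggests the direction: for compound 3 a move toward a lower number is expected, of moderate size, given as a 2.0-fold lower number from compound 2 to compound 3 (0.30 log units; within the scatter). For compound 3 the expected value in this assay is 5 mg/kg, with a range from 1.5 mg/kg to 15 mg/kg.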

Compound 3, minimum effective dose: 10 mg/kg
Beside the measured number, compound 3's estimate is 2.0-fold (0.30 log units) below it, within the range that was stated.
By their numbers in this assay, from the lowest: compound 1; then compounds 2 and 3 (each within the scatter of the next).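

In this assay, hydrogen in place of butyl on a saturated chain carbon, ten or more bonds along the chain from a saturated ring carbon, gives no change at the digits printed from compound 2 to compound 3 (within the scatter). Among these compounds, this is the first step that changes one place only, and it shows that removing butyl, with its 4 carbon atoms, from this far part of the chain leaves the read-out where it was. No measurement at hand offers an account of this result.

Going by these compounds, whether the same holds for a much shorter chain or a longer chain at this place remains open. Compound 1 differs from both methyl esters in more than one place, so the separate contribution of its butyl ester is unresolved, as is the effect of a carboxylic acid in place of the ester.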